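This account rests on a few compounds, and the source may have more. Where it says the series, first, only, none or still open, it means among the compounds named here.

Of the compounds shown here, three built on one shared core have so far been read in a physicochemical assay for solubility (on this read-out higher numbers stand for higher solubility and lower numbers for lower solubility), and none of them gives an exact number. Compound 1 `Cc1c2c(n3c1CCN(C(=O)[C@H](C)N)CC[C@H](C)Nc1cc-3ccc1C(N)=O)CC(C)(C)CC2=O` reads > 100 ug/mL, which is a limit of the assay and not a number. Compound 2 `COCCN1CC[C@H](C)Nc2cc(ccc2C(N)=O)-n2c(c(C)c3c2CC(C)(C)CC3=O)CC1=O` reads > 100 ug/mL, again a limit. Compound 3 `Cc1c2c(n3c1CC(=O)NCC[C@H](C)Nc1cc-3ccc1C(N)=O)CC(C)(C)CC2=O` reads > 100 ug/mL, also a limit, so its place can be stated no more finely than that. The whole evidence so far is the limit of > 100 ug/mL in this assay, at which 3 of the 3 values shown sit, with nothing finer behind it.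

Compound 4 `Cc1c2c(n3c1CC(=O)N(C)CC[C@H](C)Nc1cc-3ccc1C(N)=O)CC(C)(C)CC2=O` differs from compound 3 by a single change, (methyl in place of hydrogen on an amide-type nitrogen in a ring), that is, methyl in place of hydrogen on an amide-type nitrogen in a ring. Among the measured compounds shown here, the one measured step at this nitrogen is a step that the two limits leave unreadable from compound 2 to compound 3, where hydrogen replaces 2-methoxyethyl, and it gives no size to carry over. Both the substituted compound 2 and the unsubstituted compound 3 sit at the same limit in this assay, so no step beyond the usual scatter is expected here. The expected step, a step that the limit leaves unreadable from compound 3 to compound 4, is an estimate without a firm direction. Compound 4 is estimated at 150 ug/mL, with an expected range from 70 ug/mL to 400 ug/mL, and the assay will most likely report only a limit again.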

Compound 4, solubility: > 100 ug/mL
Compound 4: only a limit was reported; the forecaster's own chance of this, stated with the estimate: 80%; the middle value lies beyond the limit too.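

In this assay compound 4 gives > 100 ug/mL, which is a limit of the assay and not a number. Among the compounds shown here, no step to compound 4 can be read, either from compound 3 or from compound 2. How far compounds 1 to 4 truly differ in this assay stays open, because the evidence is a single shared limit: the limit of > 100 ug/mL in this assay, at which 4 of the 4 values shown sit.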